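The compounds below may be only part of what the source reports. "The series", "measured", "known", "first", "only" and "open" are said of these compounds alone.

In an ADME assay on Vero 76 cells (Chlorocebus sabaeus) for cytotoxicity, read by neutral red uptake (on this read-out lower numbers stand for higher toxicity in this test and higher numbers for lower toxicity in this test), compound 2 `OC[C@@]12C[C@@H]1[C@@H](n1cnc3c(NCc4ccccc4)nc(Cl)nc31)[C@H](O)[C@@H]2O` gives > 100000 nM, which is a limit of the assay and not a number. Two relatives have measured numbers: compound 1 `OC[C@@]12C[C@@H]1[C@@H](n1ccc3c(NC(C4CCC4)C4CCC4)nc(Cl)nc31)[C@H](O)[C@@H]2O` gives 86000 nM, and compound 3 `O[C@@H]1[C@H](O)[C@@H]2C[C@@H]2[C@H]1n1ccc2c(NC(C3CC3)C3CC3)nc(I)nc21` gives 44000 nM. The next compound to test is compound 4 `OC[C@@]12C[C@@H]1[C@@H](n1cnc3c(NC(C4CCC4)C4CCC4)nc(Cl)nc31)[C@H](O)[C@@H]2O`, which has dicyclobutylmethyl in place of benzyl on a nitrogen on an aromatic ring. Compound 1 also carries dicyclobutylmethyl and gives 86000 nM, which points to a small expected move toward lower numbers in this assay, meaning somewhat higher toxicity in the test. The estimated change is an at least 1.2-fold lower number from compound 2 to compound 4 (0.09 log units; that floor lies within the scatter). Compound 4 is expected at about 80000 nM, within an estimated range of 40000 nM to 100000 nM.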

Compound 4, half-maximal cytotoxic concentration: 28000 nM
Beside the measured number, compound 4's estimate is 2.9-fold (0.46 log units) above it; measured number below the stated range.
By their numbers in this assay, from the lowest: compounds 4, 3 and 1 (each within the scatter of the next, the first and the last beyond it). At a limit, above all of these: compound 2.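

In this assay, swapping benzyl for dicyclobutylmethyl on this nitrogen is the first change shown that can be read directly, with the rest of the molecule unchanged: an at least 3.5-fold lower number from compound 2 to compound 4 (0.55 log units; beyond the scatter) is the step. It shows that the group at this place alone can move the number beyond the scatter, toward higher toxicity in the test. Only the least size of this step is known, because compound 2 stands at a limit and not at a number: the limit of > 100000 nM in this assay, at which 1 of the 4 values shown sits.

Still open, as far as these compounds go, is how a single cyclobutylmethyl group, or a longer chain ending in an amine, would read at this place.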